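From benzofuran to cyclopropyl on the ring amine

The source may hold more compounds than are shown below. What is called first, only, known or untested is meant among the compounds shown, and "the series" means these compounds.

Compound 3 `Fc1ccc(C(SCCNC2CCN(Cc3cc4ccccc4o3)CC2)c2ccc(F)cc2)cc1` gives 205 nM in an assay on membranes from Cortex for displacement of a labelled ligand from Sigma non-opioid intracellular receptor 1 (Cavia porcellus), read by scintillation counting, with a stated time of 120 min (on this read-out lower numbers stand for stronger inhibition and higher numbers for weaker inhibition), the highest number of the three. Compound 1 `Fc1ccc(CN2CCC(NCCSC(c3ccc(F)cc3)c3ccc(F)cc3)CC2)cc1` gives 13.3 nM and compound 2 `O=C(c1ccc(F)cc1)N1CCC(NCCSC(c2ccc(F)cc2)c2ccc(F)cc2)CC1` gives 32.1 nM; the steps of a 2.4-fold higher number from compound 1 to compound 2 (0.38 log units; beyond the scatter), a 15-fold higher number from compound 1 to compound 3 (1.19 log units; beyond the scatter) and a 6.4-fold higher number from compound 2 to compound 3 (0.81 log units; beyond the scatter) show that the group on the amine nitrogen in a ring matters, with 1-benzofuran-2-yl the weakest of those tried. Compound 4 `Fc1ccc(C(SCCNC2CCN(CC3CC3)CC2)c2ccc(F)cc2)cc1` is not yet measured; it carries cyclopropyl in place of 1-benzofuran-2-yl on a saturated chain carbon bound to an amine nitrogen in a ring. Among the compounds with values here, no measured pair places cyclopropyl there, but since the benzofuran group was the costly one in the step of a 15-fold higher number from compound 1 to compound 3 (1.19 log units; beyond the scatter), removing it is expected to lower the number. Compound 4 is therefore estimated at 20 nM, with a range from 5 nM to 80 nM. This expected change amounts to a 10-fold lower number from compound 3 to compound 4 (1.01 log units; beyond the scatter).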

Compound 4, inhibition constant: 269 nM
The estimate for compound 4 lay 13-fold (1.13 log units) below the measured number, outside the stated range (above it).
By their numbers in this assay, from the lowest: compound 1; then compound 2; then compounds 3 and 4 (each within the scatter of the next).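

In this assay, replacing 1-benzofuran-2-yl with the far smaller cyclopropyl leaves the number within the scatter (a 1.3-fold higher number from compound 3 to compound 4 (0.12 log units; within the scatter)), so the benzofuran group alone does not account for the weaker binding of compound 3. Compound 4 remains clearly apart from the two compounds carrying a 4-fluorophenyl group (a 20-fold higher number from compound 1 to compound 4 (1.31 log units; beyond the scatter); an 8.4-fold higher number from compound 2 to compound 4 (0.92 log units; beyond the scatter)), which points to that group, not merely the absence of benzofuran, as what goes with lower numbers here. Nothing measured here explains this result. As far as these compounds go, whether an unsubstituted benzyl or a pyridinylmethyl group on the amine nitrogen in a ring would also give a low number remains open.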